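This account rests on a few compounds, and the source may have more. Where it says the series, first, only, none or still open, it means among the compounds named here.

In a functional assay on U-87MG ATCC cells for inhibition, with U-87 MG (Homo sapiens) as the target, read by MTT assay, with a stated time of 48 h (a lower number here means a stronger inhibitor, a higher number a weaker inhibitor), compound 1 (`COc1ccc(-c2nc3ccccn3c2Sc2ccccc2)cc1`) gives > 100000 nM as a limit and not a number. Compound 2 (`c1ccc(Sc2c(-c3cccs3)nc3ccccn23)cc1`) gives > 100000 nM as a limit too. Compound 3 (`Clc1ccc(Sc2c(-c3cccs3)nc3ccccn23)cc1`) gives > 100000 nM and this is likewise a limit, so no number places it. Among the measured compounds shown here, the whole series so far stands at the limit of > 100000 nM in this assay, at which 3 of the 3 values shown sit, and nothing more. Compound 4 (`Clc1ccc(Sc2c(-c3ccccc3)nc3ccccn23)cc1`) carries phenyl in place of thiophen-2-yl on an aromatic carbon at the site already changed in the first measured step. Both measured steps lack a size (a step that the two limits leave unreadable from compound 1 to compound 2 and a step that the two limits leave unreadable from compound 2 to compound 3) and so give no direction. No step beyond the scatter is expected, and the estimate means a number no higher from compound 3 to compound 4 (the limit leaves the size open) as expected here. In this assay the estimate for compound 4 is an expected 100000 nM within a range of 30000 nM to 150000 nM and it may well return as a limit again.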

Compound 4, half-maximal inhibitory concentration: 62800 nM
For compound 4 the middle estimate is 1.6-fold (0.20 log units) above the measured one; low and high end bracket the measured number.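

Phenyl in place of thiophen-2-yl on this aromatic carbon gives the first readable number of the series in this assay, with an at least 1.5-fold lower number from compound 3 to compound 4 (0.20 log units; that floor lies within the scatter). Among the compounds shown here, the floor of that step lies within the scatter, so a real gain from phenyl is not established, and the earlier steps cannot be read. The other compounds stay at a limit: the limit of > 100000 nM in this assay, at which 3 of the 4 values shown sit.

From the compounds shown here alone, whether the number for compound 4 depends on its chloro group remains open. Also open, going by these compounds, is how an amine or a carboxylic acid on the phenyl at this position would read.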